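Swapping an Amide for Fluorine at the Indole-Free Position

The source may hold more compounds than are shown below. What is called first, only, known or untested is meant among the compounds shown, and "the series" means these compounds.

Measured compounds in a functional assay on K562 cells (Homo sapiens) for antiproliferative activity, read by CCK-8 assay, with a stated time of 72 h; on this read-out lower numbers stand for stronger inhibition of growth and higher numbers for weaker inhibition of growth:
compound 1 `CCC1C(=O)N(C)c2cnc(-n3ccc4cc(C(=O)NC(C)C)ccc43)nc2N1c1ccn(C)n1` gives 8910 nM
compound 2 `CCC1C(=O)N(C)c2cnc(Nc3ccc(S(=O)(=O)NCCO)cc3)nc2N1c1ccn(C)n1` gives "not active" (no number reported)
compound 3 `CCC1C(=O)N(C)c2cnc(-n3ccc4cc(C(=O)NC)ccc43)nc2N1c1ccn(C)n1` gives 13300 nM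

Of the two numbers reported in this assay, the higher one belongs to compound 3, yet the measured step between these two is a 1.5-fold higher number from compound 1 to compound 3 (0.17 log units; within the scatter), so the two cannot be ranked. Compound 2 is recorded as not active, without a number.

Compound 4 `CCC1C(=O)N(C)c2cnc(-n3ccc4cc(F)ccc43)nc2N1c1ccn(C)n1` differs from compound 3 in one place: fluoro in place of methylcarbamoyl on an aromatic carbon. Among the compounds with values here, only one measured step touches the same part of the molecule, the one from compound 1 to compound 3, where the isopropyl on the amide-type nitrogen became methyl; it was a 1.5-fold higher number from compound 1 to compound 3 (0.17 log units; within the scatter), within the scatter. That step, however, kept the methylcarbamoyl group with its hydrogen-bond donor and acceptor, whereas here the whole group departs and a fluoro enters. Within the data shown here, no measured step shows what removing the amide does, so the direction is open and the range must be wide.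

Compound 4 is therefore estimated to give 22000 nM, between 6000 nM and 90000 nM, which means an expected step of a 1.7-fold higher number from compound 3 to compound 4 (0.22 log units; within the scatter) from compound 3.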

Compound 4, concentration for 50% growth inhibition: 6070 nM
Estimate against measurement, compound 4: 3.6-fold (0.56 log units) above, within the range that was stated.
By their numbers in this assay, from the lowest: compounds 4, 1 and 3 (each within the scatter of the next, the first and the last beyond it).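

In this assay, the amide group on this aromatic carbon turns out not to be required for the growth inhibition seen so far: replacing methylcarbamoyl with fluoro gives a 2.2-fold lower number from compound 3 to compound 4 (0.34 log units; beyond the scatter), a modest step, but one that lies beyond the usual scatter. Replacing the isopropylcarbamoyl group with fluoro gives a 1.5-fold lower number from compound 1 to compound 4 (0.17 log units; within the scatter), so compound 1 and compound 4 cannot be ranked, and in neither pair does losing the amide, with its hydrogen-bond donor and acceptor, raise the number. The earlier step between the two amides changed only the group on the amide nitrogen, whereas these steps remove the whole group, and no available evidence explains their outcome.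

The compounds shown cannot separate the effect of adding fluoro from that of simply losing the amide, a question that a plain hydrogen, a chlorine or a nitrile on this aromatic carbon could help to answer. They also leave open how an amine, a carboxylic acid or a longer chain ending in an alcohol would behave at this position on the same core.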